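From Isopropyl to But-2-yn-1-yl on the Amine Nitrogen

The source may hold more compounds than are shown below. What is called first, only, known or untested is meant among the compounds shown, and "the series" means these compounds.

Compound 1 `NCCCSC[C@H]1O[C@@H](n2cnc3c(N)ncnc32)[C@H](O)[C@@H]1O`: no result reported
Compound 2 `Nc1ncnc2c1ncn2[C@@H]1O[C@H](CNC(=O)CC[C@H](N)C(=O)O)[C@@H](O)[C@H]1O`: no result reported
Compound 3 `CC(C)N(CC[C@H](N)C(=O)O)C[C@H]1O[C@@H](n2cnc3c(N)ncnc32)[C@H](O)[C@@H]1O`: 44%

Among the measured compounds shown here, three compounds share one core, yet only one carries a number. In an assay for inhibition of tRNA (cytosine(38)-C(5))-methyltransferase (Homo sapiens), with a stated time of 5 min, tested at 100 uM (on this read-out lower numbers stand for less inhibition and higher numbers for more inhibition at the one concentration tested (going by the name of the read-out)), compound 3 gives 44%, a moderate degree of inhibition at the single concentration tested. Compound 1 and compound 2 have no result in this assay, so compound 3 stands alone, with nothing to rank it against. Compound 4 `CC#CCN(CC[C@H](N)C(=O)O)C[C@H]1O[C@@H](n2cnc3c(N)ncnc32)[C@H](O)[C@@H]1O` differs from compound 3 in one place: but-2-yn-1-yl in place of isopropyl on an amine nitrogen. For the measured compounds named here, no measured pair shows what such a swap does in this assay, so the size of the step can only be guessed; a shift within the usual scatter, in either direction, seems the most reasonable expectation. The expected step is a number 1 percentage points higher from compound 3 to compound 4 (within the scatter). Compound 4 is estimated at 45%, within a range from 20% to 70%.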

Compound 4, a percentage reported as inhibition, at one concentration (the size of the read-out at that concentration, not a potency): 61.3%
The estimate for compound 4 lay 16.3 percentage points below the measured number, and the stated range covers the measured number.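

In this assay, among the compounds shown here, putting but-2-yn-1-yl in place of isopropyl on the amine nitrogen gives a number 17.3 percentage points higher from compound 3 to compound 4 (beyond the scatter) and provides the first measured pair for this position. It shows that the read-out responds to the group at this nitrogen. Nothing shown gives a reason for the step.

From the compounds shown here alone, whether the triple bond or the additional carbon matters stays open. A butyl or but-2-en-1-yl group on this nitrogen would help separate the two, and a longer chain would test whether the trend continues.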